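The source may report more compounds than this note shows. Statements on the series, on what has been measured and on what is new or still open speak of the compounds shown alone.

Working notes on the series. Compound 1 `O=C(c1ccc(C(F)(F)F)cc1)N1CCC(NS(=O)(=O)c2cc(S(=O)(=O)c3ccccc3)ccc2C(F)(F)F)CC1` gives 400 nM in an assay on isolated protein for displacement of a labelled ligand from secreted frizzled-related protein 1 (Homo sapiens), read by fluorescence polarization, with a stated time of 30 min; on this read-out lower numbers stand for stronger inhibition and higher numbers for weaker inhibition. Compound 2 `CN(C)c1ccc(C(=O)N2CCC(NS(=O)(=O)c3cc(S(=O)(=O)c4ccccc4)ccc3C(F)(F)F)CC2)cc1` gives 300 nM in this assay; the step of a 1.3-fold lower number from compound 1 to compound 2 (0.12 log units; within the scatter) is within the scatter. Compound 3 `O=C(c1ccc(Cl)nc1)N1CCC(NS(=O)(=O)c2cc(S(=O)(=O)c3ccccc3)ccc2C(F)(F)F)CC1` gives 110 nM in this assay, the lowest of the three numbers, reached by the steps of a 3.6-fold lower number from compound 1 to compound 3 (0.56 log units; beyond the scatter) and a 2.7-fold lower number from compound 2 to compound 3 (0.44 log units; beyond the scatter).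

Compound 4 `O=C(O)c1cccc(S(=O)(=O)N2CCC(NS(=O)(=O)c3cc(S(=O)(=O)c4ccccc4)ccc3C(F)(F)F)CC2)c1` has not yet been measured. It differs from compound 3 by (3-carboxyphenyl)sulfonyl in place of (6-chloropyridin-3-yl)carbonyl on an amine nitrogen in a ring. The measured steps each exchange one aromatic group on the carbonyl carbon and stay modest; none exchanges the carbonyl itself for a sulfonyl or brings in a carboxy group, so they give a scale but no direction. The change from compound 3 to compound 4 is larger than any measured one, and a step of either sign beyond the scatter is possible. Among the compounds with values here, with no closer precedent, compound 4 is expected to sit near the measured compounds, a step of a 2.7-fold higher number from compound 3 to compound 4 (0.44 log units; beyond the scatter). Compound 4 is estimated at 300 nM, within 80 nM to 1200 nM.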

Compound 4, half-maximal inhibitory concentration: 20 nM
The estimate for compound 4 lay 15-fold (1.18 log units) above the measured number; measured number outside the range, below it.
By their numbers in this assay, from the lowest: compound 4; then compound 3; then compounds 2 and 1 (each within the scatter of the next).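

The amine nitrogen in a ring accepts more than an aromatic carbonyl group: in this assay, (3-carboxyphenyl)sulfonyl in place of (6-chloropyridin-3-yl)carbonyl gives a 5.5-fold lower number from compound 3 to compound 4 (0.74 log units; beyond the scatter), and the same group in place of the other two carbonyl groups gives a 15-fold lower number from compound 2 to compound 4 (1.18 log units; beyond the scatter) and a 20-fold lower number from compound 1 to compound 4 (1.30 log units; beyond the scatter). Each of these steps is larger than any step among compound 1, compound 2 and compound 3, so this position can carry a wider range of numbers than the earlier exchanges of aromatic groups showed. Nothing available explains the size of these steps.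

The change brings in the sulfonyl and the carboxy group together, so the compounds shown cannot divide the steps between them; a (3-carboxyphenyl)carbonyl group or a plain phenylsulfonyl group would separate the two. As far as these compounds go, whether the carboxylic acid itself is needed stays open, and a methyl ester or a primary amide in its place would test that.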